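A few compounds are considered here, and "the series" means these few. Any claim that something is new, unique, unknown or untested is made for them only; others in the source may bear on it.

In a functional assay on MDA-MB-231 cells (Homo sapiens) for cytotoxicity, read by MTT assay, with a stated time of 72 h (a higher number here means a weaker inhibitor, a lower number a stronger inhibitor), the measured compounds stand as follows:

compound 1 `Cn1nc(-c2ccccc2)c2cc(C(=N)Nc3ccccc3)ncc21`: 11100 nM
compound 2 `COc1ccc(Cn2nc(-c3ccccc3)c3cc(C(=N)Nc4ccccc4)ncc32)cc1`: 5400 nM
compound 3 `N=C(Nc1ccccc1)c1cc2c(-c3ccccc3)n[nH]c2cn1`: 11000 nM

Compound 1 gives the highest number of the three; compound 3 sits within the scatter of it, and compound 2 is the only one set apart, by a 2.1-fold lower number from compound 1 to compound 2 (0.31 log units; beyond the scatter). The other steps, a 1.0-fold lower number from compound 1 to compound 3 (0.00 log units; within the scatter) and a 2.0-fold higher number from compound 2 to compound 3 (0.31 log units; beyond the scatter), likewise concern only the group on the aromatic nitrogen of the shared core.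

Compound 4 `CN1CCN(c2ccc(NC(=N)c3cc4c(-c5ccccc5)nn(C)c4cn3)cc2)CC1` differs from compound 1 at another site: 4-methylpiperazin-1-yl in place of hydrogen on an aromatic carbon. Among the measured compounds shown here, none of the measured steps touches that ring, so nothing here speaks for a change in either direction. Compound 4 is therefore expected to stay near compound 1, with a step of a 1.2-fold lower number from compound 1 to compound 4 (0.09 log units; within the scatter), giving an estimate of 9000 nM (range 3000 nM to 27000 nM).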

Compound 4, half-maximal inhibitory concentration: 4900 nM
Beside the measured number, compound 4's estimate is 1.8-fold (0.26 log units) above it; the range from low to high includes it.
By their numbers in this assay, from the lowest: compounds 4 and 2 (each within the scatter of the next); then compounds 3 and 1 (each within the scatter of the next).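

In this assay, among the compounds shown here, 4-methylpiperazin-1-yl in place of hydrogen gives a 2.3-fold lower number from compound 1 to compound 4 (0.36 log units; beyond the scatter) at a site the earlier steps never touched. For the compounds shown here, this is the first sign that the six-membered aromatic ring of carbon only has a bearing on the number, although the step is modest. Nothing available explains the step.

Going by these compounds, whether a morpholine ring, a dimethylamino group or a carboxylic acid at that place would give a similar step remains open. So does whether this change and the 4-methoxybenzyl group of compound 2 would add up in one molecule.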